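This account rests on a few compounds, and the source may have more. Where it says the series, first, only, none or still open, it means among the compounds named here.

Measured in a functional assay on DU-145 cells (Homo sapiens) for inhibition; a higher number here means a weaker inhibitor, a lower number a stronger inhibitor:

compound 1 `Oc1cccc(-c2cc(-c3ccc(F)cc3)cc(-c3ccccc3O)n2)c1`, > 50000 nM, a limit of the assay
compound 2 `Oc1ccc(-c2cc(-c3ccc(F)cc3)cc(-c3ccccc3O)n2)cc1`, > 50000 nM, a limit of the assay
compound 3 `Oc1ccc(-c2cc(-c3ccc(F)cc3)cc(-c3cccc(O)c3)n2)cc1`, 15200 nM

Compound 2 stands at the limit of > 50000 nM in this assay, at which 2 of the 3 values shown sit, so for it only a limit and no number is known. The step that the two limits leave unreadable from compound 1 to compound 2 is therefore unreadable; the steps of an at least 3.2-fold lower number from compound 1 to compound 3 (0.51 log units; beyond the scatter) and an at least 3.2-fold lower number from compound 2 to compound 3 (0.51 log units; beyond the scatter) are at least modest, and both concern the position of the hydroxyl on one of the hydroxyphenyl groups.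

Compound 4 `Oc1ccc(-c2cc(-c3cccc(C(F)(F)F)c3)cc(-c3ccccc3O)n2)cc1` differs from compound 2 at another place: 3-(trifluoromethyl)phenyl in place of 4-fluorophenyl on an aromatic carbon. Within the data shown here, none of the measured steps touches this group, so no measured step bears on it directly; the three measured compounds share the 4-fluorophenyl group. Among the measured compounds shown here, what is known is only that compound 2 sits at a limit, and the expected step of a number no higher from compound 2 to compound 4 (the limit leaves the size open) is set to stay within the scatter, since no measured change at this position gives grounds for a direction. Compound 4 is therefore expected at about 50000 nM in this assay, within a range from 15000 nM to 200000 nM, most likely again reported only as a limit.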

Compound 4, half-maximal inhibitory concentration: > 50000 nM
Compound 4 gave a limit, no number; the forecaster's own chance of this, stated with the estimate: 70%; the middle value sits exactly at the limit.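

In this assay compound 4 gives > 50000 nM, a limit and not a number. Compound 2 also sits at a limit, so the step from compound 2 to compound 4 cannot be read: the limit of > 50000 nM in this assay, at which 3 of the 4 values shown sit. The compounds shown leave open whether 3-(trifluoromethyl)phenyl in place of 4-fluorophenyl changes inhibition at all.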